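Replacing Ethoxycarbonyl with Carboxy on Compound 1

The compounds below may be only part of what the source reports. "The series", "measured", "known", "first", "only" and "open" are said of these compounds alone.

Among the compounds with values here, in a functional assay on a cell-free system (Platelet, plasma, Oryctolagus cuniculus) for inhibition, with a stated time of 5 min (a lower number here means a stronger inhibitor, a higher number a weaker inhibitor), compound 1 `CCOC(=O)/C=C/c1ccc(OCc2nc(C)c(C)nc2C)c(O)c1` gives 1380000 nM, the higher of the two numbers so far and so the weaker inhibitor, while compound 2 `CCOC(=O)/C=C/c1cc(OC)c(OCc2nc(C)c(C)nc2C)c(OC)c1` gives 631000 nM. Compound 3 `Cc1nc(C)c(COc2ccc(/C=C/C(=O)O)cc2O)nc1C` has not yet been measured. It carries hydrogen in place of ethyl on an oxygen next to a carbonyl group, which turns ethoxycarbonyl into carboxy. Within the data shown here, no measured pair shows this change, so only a small step toward a lower number is expected, perhaps none beyond the scatter. The estimated change is a 1.7-fold lower number from compound 1 to compound 3 (0.24 log units; within the scatter). The value expected in this assay for compound 3 is 800000 nM, within an estimated range of 200000 nM to 2500000 nM.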

Compound 3, half-maximal inhibitory concentration: 176000 nM
The estimate for compound 3 lay 4.5-fold (0.66 log units) above the measured number, outside the stated range (below it).
By their numbers in this assay, from the lowest: compound 3; then compound 2; then compound 1.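

In this assay, replacing ethoxycarbonyl with carboxy gives a 7.8-fold lower number from compound 1 to compound 3 (0.89 log units; beyond the scatter), the first measured sign that the group on this oxygen next to a carbonyl group matters for inhibition. The step lies beyond the usual scatter, so it is more than repeat-to-repeat variation. Nothing measured here explains why the number falls.

Going by these compounds, whether the lower number depends on the carboxy hydrogen or simply on losing ethyl remains open, and a methyl ester or a primary amide in this place would help separate the two. On these data alone, whether the same change would lower the number for compound 2 is also open.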